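A few compounds are considered here, and "the series" means these few. Any claim that something is new, unique, unknown or untested is made for them only; others in the source may bear on it.

Compound 1 `CS(=O)(=O)NC(=O)c1ccc(C2CC2c2ccc(OCc3c(-c4c(Cl)cccc4Cl)noc3C3CC3)cc2Cl)cc1` is examined in an assay on HEK293 cells for agonist activity at Bile acid receptor (Homo sapiens) (a lower number here means a smaller maximal response, a higher number a larger maximal response), where compound 1 gives 88%. Of the two measured compounds it has the higher number: compound 2 `O=C(O)c1cncc(N2CC(O)(c3ccc(OCc4c(-c5c(Cl)cccc5Cl)noc4C4CC4)cc3Cl)C2)c1` gives 71% in this assay, a gap beyond the scatter. Compound 3 `O=C(O)CNC(=O)c1ccc(C2CC2c2ccc(OCc3c(-c4c(Cl)cccc4Cl)noc3C3CC3)cc2Cl)cc1` differs from compound 1 by carboxymethyl in place of methylsulfonyl on an amide-type nitrogen. Among the compounds with values here, no measured pair shows this exact change, so the step in this assay from compound 1 to compound 3 is expected to be small, not clearly beyond the scatter in either direction, as a number 4 percentage points lower from compound 1 to compound 3 (within the scatter). Compound 3 is therefore estimated at 84%, with a range from 68% to 100%.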

Compound 3, largest response reached (reported as efficacy), in percent of the reference or control that the assay uses: 58%
Compound 3: the middle estimate sits 26 percentage points above what was measured, and the stated range ends above it.
By their numbers in this assay, from the lowest: compound 3; then compound 2; then compound 1.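

The amide-type nitrogen proves to be a place where the substituent matters in this assay: carboxymethyl in place of methylsulfonyl gives a number 30 percentage points lower from compound 1 to compound 3 (beyond the scatter). Within the data shown here, this is the first comparison here in which only one place differs, and the drop appears even though both groups hold 4 heavy atoms. Nothing available explains why the maximal response falls. Still open, from the compounds shown here alone, is how ethylsulfonyl or phenylsulfonyl would fare on this nitrogen. Also open, going by these compounds, is whether a longer chain ending in a carboxylic acid would follow carboxymethyl.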